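This account rests on a few compounds, and the source may have more. Where it says the series, first, only, none or still open, it means among the compounds named here.

Compound 1 `CS(=O)(=O)c1coc(C(=O)CCCCCCc2ccccc2)n1` and compound 2 `O=C(CCCCCCc1ccccc1)c1nc(Cl)co1` share one core, while compound 3 `CS(=O)(=O)c1cnc(C(=O)CCCCCCc2ccccc2)o1` and compound 4 `O=C(CCCCCCc1ccccc1)c1ncc(Cl)o1` share another; the difference between the two cores is not broken down here. In an assay on HEK-293T cells for inhibition of diacylglycerol lipase-alpha (Homo sapiens), read by colorimetric assay (a lower number here means a stronger inhibitor, a higher number a weaker inhibitor), compound 1 gives 389 nM and compound 2 gives 2400 nM, so that a 6.2-fold higher number from compound 1 to compound 2 (0.79 log units; beyond the scatter); the change is chloro in place of methylsulfonyl on an aromatic carbon. Compound 3 reaches only a limit of the assay, > 10000 nM, which is the limit of > 10000 nM in this assay, at which 1 of the 3 values shown sits. Compound 4 carries the same kind of change, (chloro in place of methylsulfonyl on an aromatic carbon), though here the place lies next to the ring oxygen and two ring bonds from the ring nitrogen, rather than next to the ring nitrogen and two ring bonds from the ring oxygen. The expected step is a step that the limit leaves unreadable from compound 3 to compound 4, because a 6.2-fold higher number from compound 1 to compound 2 (0.79 log units; beyond the scatter). Compound 4 is therefore expected to give around 30000 nM, between 10000 nM and 100000 nM, most probably reported only as a limit.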

Compound 4, half-maximal inhibitory concentration: > 10000 nM
Compound 4 was reported as a limit (the forecaster's own chance of this, stated with the estimate: 85%); the middle value is on the limit's open side.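

In this assay compound 4 gives > 10000 nM as a limit of the assay, not a number. As far as these compounds go, whether chloro in place of methylsulfonyl has the same effect on both cores therefore stays unknown, and the step from compound 3 to compound 4 cannot be read, because both compounds sit at the limit: the limit of > 10000 nM in this assay, at which 2 of the 4 values shown sit. What can be read is an at least 4.1-fold higher number from compound 2 to compound 4 (0.61 log units; beyond the scatter) with 5-chloro-1,3-oxazol-2-yl in place of 4-chloro-1,3-oxazol-2-yl, which compares the two chloro compounds but does not size the change on the core of compound 3.

From the compounds shown here alone, whether any group on that core gives a value inside the assay's range stays open. A nitrile or a carboxylic acid in place of the chloro could test this.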